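Returning to an aryl amide after a weak benzyl amide

A few compounds are considered here, and "the series" means these few. Any claim that something is new, unique, unknown or untested is made for them only; others in the source may bear on it.

Compound 1, `COc1ccc2c(=O)c(/C=C/C(=O)Nc3ccccc3Cl)coc2c1`: 29900 nM
Compound 2, `COc1ccc2c(=O)c(/C=C/C(=O)NCc3cccc(F)c3)coc2c1`: 26900 nM
Compound 3, `COc1ccc2c(=O)c(/C=C/C(=O)NCc3ccccc3F)coc2c1`: > 100000 nM

The three compounds share one core and differ only in the group carried on the amide-type nitrogen. In a functional assay on A549 cells (Homo sapiens) for inhibition, read by MTT assay, with a stated time of 48 h (on this read-out higher numbers stand for weaker inhibition and lower numbers for stronger inhibition), compound 1 gives 29900 nM and compound 2 gives 26900 nM; the step of a 1.1-fold lower number from compound 1 to compound 2 (0.05 log units; within the scatter) therefore shows no real difference between these two. For compound 3 the read-out is only a limit of the assay, (the limit of > 100000 nM in this assay, at which 1 of the 3 values shown sits), so its number is not known beyond that. Both steps into compound 3 point the same way: an at least 3.3-fold higher number from compound 1 to compound 3 (0.52 log units; beyond the scatter), and an at least 3.7-fold higher number from compound 2 to compound 3 (0.57 log units; beyond the scatter). Compound 3 thus stands at the weak end of what has been measured.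

The next change is 4-fluorophenyl in place of 2-fluorobenzyl on an amide-type nitrogen, giving compound 4, `COc1ccc2c(=O)c(/C=C/C(=O)Nc3ccc(F)cc3)coc2c1`. Compound 4 places a fluorophenyl directly on the nitrogen, as compound 1 does with a chlorophenyl, and removes the saturated carbon that compound 3 carries. Since compound 1 sits at 29900 nM, compound 4 is expected to come back toward that region, which would mean a step of an at least 3.3-fold lower number from compound 3 to compound 4 (0.52 log units; beyond the scatter). The estimate for compound 4 in this assay is 30000 nM, with a range from 10000 nM to 100000 nM.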

Compound 4, half-maximal inhibitory concentration: 26800 nM
Compound 4: the middle estimate sits 1.1-fold (0.05 log units) above what was measured; low and high end bracket the measured number.
By their numbers in this assay, from the lowest: compounds 4, 2 and 1 (each within the scatter of the next). At a limit, above all of these: compound 3.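

Replacing 2-chlorophenyl with 4-fluorophenyl on the amide-type nitrogen gives a 1.1-fold lower number from compound 1 to compound 4 (0.05 log units; within the scatter), so these two aryl amides, which differ in both the halogen and its ring position, cannot be told apart on this read-out. Replacing 3-fluorobenzyl with 4-fluorophenyl gives a 1.0-fold lower number from compound 2 to compound 4 (0.00 log units; within the scatter), so a benzyl amide and an aryl amide can fall in the same range, and the weak reading of the 2-fluorobenzyl amide does not extend to every benzyl amide shown. The 2-fluorobenzyl group alone stands apart, with an at least 3.7-fold lower number from compound 3 to compound 4 (0.57 log units; beyond the scatter), and that step starts from a limit of the assay rather than a number: the limit of > 100000 nM in this assay, at which 1 of the 4 values shown sits.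

From the compounds shown here alone, every aromatic ring on the nitrogen here carries a single halogen, so it remains open whether an unsubstituted phenyl, or a ring bearing a methoxy group or a nitrile, would give a number beyond the scatter of these three. Also open, going by these compounds, are how a longer chain, such as 2-phenylethyl, would read and how far past its limit the true value of compound 3 lies.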